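Swapping the anilino substituent on a shared cyanopyrimidine core

This account rests on a few compounds, and the source may have more. Where it says the series, first, only, none or still open, it means among the compounds named here.

Compound 2 `COc1ccccc1Nc1nc(SCc2cn(CC(=O)NC(=O)Nc3ccccn3)nn2)nc(-c2ccc(C)cc2)c1C#N`: 19700 nM
Compound 1 `COc1cc(-c2nc(SCc3cn(CC(=O)NC(=O)Nc4ccccn4)nn3)nc(Nc3cccc(C(F)(F)F)c3)c2C#N)cc(OC)c1OC`: 8140 nM

In a functional assay on MCF7 cells (Homo sapiens) for inhibition, read by MTT assay, with a stated time of 72 h (a lower number here means a stronger inhibitor, a higher number a weaker inhibitor), compound 2 gives 19700 nM, the higher of the two numbers; compound 1 sits at 8140 nM, a difference beyond the scatter. Compound 3 `Cc1ccc(-c2nc(SCc3cn(CC(=O)NC(=O)Nc4ccccn4)nn3)nc(Nc3cccc(C(F)(F)F)c3)c2C#N)cc1` is not yet measured. It keeps the core of compound 2 but carries 3-(trifluoromethyl)phenyl in place of 2-methoxyphenyl on a nitrogen on an aromatic ring. Going by the values given here, that brings in the same anilino group found in compound 1, which gives 8140 nM; the two measured compounds differ elsewhere as well, so no clean step is known. A modest move toward a lower number, a 2.0-fold lower number from compound 2 to compound 3 (0.29 log units; within the scatter), is expected. Compound 3 is estimated at 10000 nM, within 4000 nM to 25000 nM.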

Compound 3, half-maximal inhibitory concentration: 6120 nM
Beside the measured number, compound 3's estimate is 1.6-fold (0.21 log units) above it, within the range that was stated.
By their numbers in this assay, from the lowest: compounds 3 and 1 (each within the scatter of the next); then compound 2.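

In this assay the change on the nitrogen can now be read on its own: 3-(trifluoromethyl)phenyl in place of 2-methoxyphenyl gives a real gain (a 3.2-fold lower number from compound 2 to compound 3 (0.51 log units; beyond the scatter)). On the aromatic carbon, 4-methylphenyl in place of 3,4,5-trimethoxyphenyl makes no difference that can be told apart (a 1.3-fold lower number from compound 1 to compound 3 (0.12 log units; within the scatter)). Nothing available explains either step.

As far as these compounds go, whether the step comes from gaining the trifluoromethyl group or losing the methoxy group stays open. So does how a plain phenyl or a cyclohexyl group on that nitrogen would compare.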